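This account rests on a few compounds, and the source may have more. Where it says the series, first, only, none or still open, it means among the compounds named here.

Measured compounds:
compound 1, `C=C(Br)C(=O)Nc1cccc(-c2cn3nc(Cc4cccc(OC)c4)sc3n2)c1`: 1100 nM
compound 2, `COc1ccc(-c2csc3nc(-c4cccc(N)c4)cn23)cc1`: 11000 nM
compound 3, `COc1cccc(Cc2nn3cc(-c4cccc(N)c4)nc3s2)c1`: 10000 nM

These three compounds were tested in a functional assay on FM3A cells (Mus musculus) for inhibition, read by cell counting, with a stated time of 2 days; a lower number here means a stronger inhibitor, a higher number a weaker inhibitor. Compound 1 gives the lowest number of the three; compound 3 stands nearest, and compound 2 furthest from it. Going by the values given here, the one step between compounds that differ in a single place is a 9.1-fold higher number from compound 1 to compound 3 (0.96 log units; beyond the scatter).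

Compound 4, `C=C(Br)C(=O)Nc1cccc(-c2cn3nc(-c4ccc(Cl)cc4)sc3n2)c1`, has not yet been measured in this assay. It differs from compound 1 in one place: 4-chlorophenyl in place of 3-methoxybenzyl on an aromatic carbon. Among the compounds with values here, no measured step speaks to this change directly, since the only recorded step concerns the group on the nitrogen. Compounds 2 and 3 carry different groups on the shared core and give numbers that lie within the usual scatter of each other, which offers only a weak hint that swapping the group on this side of the core changes little. For compound 4 the expected step is therefore a 1.4-fold higher number from compound 1 to compound 4 (0.13 log units; within the scatter), not beyond the scatter. Compound 4 is estimated at 1500 nM, with a range from 400 nM to 6000 nM.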

Compound 4, half-maximal inhibitory concentration: 2000 nM
Compound 4: the middle estimate sits 1.3-fold (0.12 log units) below what was measured; measured number inside the range.
By their numbers in this assay, from the lowest: compounds 1 and 4 (each within the scatter of the next); then compounds 3 and 2 (each within the scatter of the next).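

Going by these compounds alone, this is the first step in this assay that changes only the group on this aromatic carbon of the shared core, and the result (a 1.8-fold higher number from compound 1 to compound 4 (0.26 log units; within the scatter)) leaves compound 1 and compound 4 indistinguishable. Two groups that differ in heavy-atom count and in hydrogen-bond acceptors, one carrying oxygen and the other chlorine, therefore give numbers within the scatter of each other, whereas the step at the nitrogen was beyond it. No available evidence explains this result.

Because this single change alters the linking carbon, the ring substituent and its ring position together, the contribution of each stays unresolved. Going by these compounds, both groups here carry an aromatic ring, so it also remains open how an amine, a carboxylic acid or a longer chain on this carbon would read out.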